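Methylsulfanyl Replaces Methylamino in an Inactive Series

The compounds below may be only part of what the source reports. "The series", "measured", "known", "first", "only" and "open" are said of these compounds alone.

Three compounds share one core and differ only in the group on an aromatic carbon. Compound 1 `CNc1ncnc2c1c(-c1cccs1)cn2[C@@H]1O[C@H](CO)[C@@H](O)[C@H]1O` carries a thiophen-2-yl group, compound 2 `CNc1ncnc2c1c(-c1ccoc1)cn2[C@@H]1O[C@H](CO)[C@@H](O)[C@H]1O` a furan-3-yl group, and compound 3 `C#Cc1cn([C@@H]2O[C@H](CO)[C@@H](O)[C@H]2O)c2ncnc(NC)c12` an ethynyl group. In a functional assay on HCT-116 cells (Homo sapiens), read by MTT assay, with a stated time of 72 h (on this read-out higher numbers stand for weaker inhibition and lower numbers for stronger inhibition), compound 1 gives > 20000 nM, which is a limit of the assay rather than a number. Compound 2 likewise gives > 20000 nM, again a limit. Compound 3 gives > 20000 nM, also a limit. The steps between them, a step that the two limits leave unreadable from compound 1 to compound 2, a step that the two limits leave unreadable from compound 1 to compound 3 and a step that the two limits leave unreadable from compound 2 to compound 3, cannot be read, since (the limit of > 20000 nM in this assay, at which 3 of the 3 values shown sit). Compound 2 therefore stands alongside the other two at the limit, and the numbers separate none of them.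

Compound 4 `CSc1ncnc2c1c(-c1ccoc1)cn2[C@@H]1O[C@H](CO)[C@@H](O)[C@H]1O` is not yet measured. It differs from compound 2 by methylsulfanyl in place of methylamino on an aromatic carbon. Among the measured compounds shown here, no measured step touches this position, so the measured steps offer no guide to its size or direction; the only evidence is that every compound sharing the core so far sits at the limit. Compound 4 is therefore expected to remain at or near that limit, with a step of a number no higher from compound 2 to compound 4 (the limit leaves the size open) that is expected to be small. The estimate for compound 4 is 20000 nM, within 8000 nM to 60000 nM.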

Compound 4, half-maximal inhibitory concentration: 40 nM
Beside the measured number, compound 4's estimate is 500-fold (2.70 log units) above it; the measured number lies below the stated range.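

In this assay, the group on the aromatic carbon next to the ring nitrogen turns out to matter a great deal: methylsulfanyl in place of methylamino gives an at least 500-fold lower number from compound 2 to compound 4 (2.69 log units; beyond the scatter). With the furan-3-yl group held fixed, this single change is enough to turn a compound sitting at the limit of the assay into one with a measurable value, so the methylamino compounds could not show what the core can do. Their steps cannot be read, because thiophen-2-yl, furan-3-yl and ethynyl all left the value at the same limit: the limit of > 20000 nM in this assay, at which 3 of the 4 values shown sit.

The compounds shown leave open whether the gain comes from the sulfur, from the loss of the hydrogen-bond donor that methylamino carries and methylsulfanyl lacks, or from both, and a methoxy or a dimethylamino group at this position would help to separate these. They also leave open whether methylsulfanyl has a similar effect alongside thiophen-2-yl or ethynyl, and whether a longer chain on the sulfur, such as ethylsulfanyl, would keep it.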